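Methyl(phenyl)amino in Place of Amino on the Sulfonyl Sulfur

The source may hold more compounds than are shown below. What is called first, only, known or untested is meant among the compounds shown, and "the series" means these compounds.

Compound 1 `CC1(C)C=C(n2ccccc2=O)c2cc(S(N)(=O)=O)ccc2O1` gives 77.5% in a functional assay on the whole organism (aorta) with Rattus norvegicus as the target (on this read-out lower numbers stand for smaller maximal responses and higher numbers for larger maximal responses), and stands second highest of the three measured numbers. Its nearest neighbour is compound 3 `CN(C)S(=O)(=O)c1ccc2c(c1)C(n1ccccc1=O)=CC(C)(C)O2` with 78.3%, the step being a number 0.8 percentage points higher from compound 1 to compound 3 (within the scatter); its furthest is compound 2 `CCNS(=O)(=O)c1ccc2c(c1)C(n1ccccc1=O)=CC(C)(C)O2` with 72.4%, the step being a number 5.1 percentage points lower from compound 1 to compound 2 (within the scatter). Compound 4 `CN(c1ccccc1)S(=O)(=O)c1ccc2c(c1)C(n1ccccc1=O)=CC(C)(C)O2` has not yet been measured in this assay. It differs from compound 1 by methyl(phenyl)amino in place of amino on a sulfonyl sulfur.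

Among the measured compounds shown here, three measured steps touch the same sulfonamide nitrogen. Replacing the nitrogen hydrogen with ethyl gave a number 5.1 percentage points lower from compound 1 to compound 2 (within the scatter), replacing amino with dimethylamino gave a number 0.8 percentage points higher from compound 1 to compound 3 (within the scatter), and moving from ethylamino to dimethylamino gave a number 5.9 percentage points higher from compound 2 to compound 3 (within the scatter). All three lie within the scatter, so nothing among these compounds points to a step beyond it, and the methyl(phenyl)amino group brings in a ring with no precedent among them. Compound 4 is therefore expected to show a number 2.5 percentage points lower from compound 1 to compound 4 (within the scatter), and its value is estimated at 75%, between 60% and 88%.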

Compound 4, largest response reached (Emax), in percent of the reference or control that the assay uses: 64.2%
Beside the measured number, compound 4's estimate is 10.8 percentage points above it, and the stated range covers the measured number.
By their numbers in this assay, from the lowest: compounds 4, 2, 1 and 3 (each within the scatter of the next, the first and the last beyond it).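

In this assay, among the compounds shown here, the sulfonamide nitrogen had taken ethyl and dimethylamino changes with no step beyond the scatter, and methyl(phenyl)amino is the first group at this place to give one: a number 13.3 percentage points lower from compound 1 to compound 4 (beyond the scatter) and, with phenyl in place of methyl as the single change, a number 14.1 percentage points lower from compound 3 to compound 4 (beyond the scatter). The change from ethylamino stays inside the scatter, a number 8.2 percentage points lower from compound 2 to compound 4 (within the scatter), so compound 4 stands apart from compound 1 and compound 3 but not from compound 2. Nothing measured here bears on why this happens.

Still open, on these data alone, is whether the step belongs to the aromatic ring itself, which phenylamino without the methyl, benzyl or cyclohexyl on the same nitrogen could test. As far as these compounds go, it is also open whether a substituted phenyl, such as methoxyphenyl, would give a step of similar size.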